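The source may hold more compounds than are shown below. What is called first, only, known or untested is meant among the compounds shown, and "the series" means these compounds.

Of the compounds shown here, two sharing one core have been measured in a functional assay on U-87MG ATCC cells for antiproliferative activity against U-87 MG (Homo sapiens), read by MTT assay, with a stated time of 48 h, tested at 50 uM; on this read-out lower numbers stand for a stronger effect and higher numbers for a weaker effect at the one concentration tested. Compound 1, `COc1ccc(-c2nc(SCC(=O)c3sc(-c4ccccc4)nc3C)[nH]c(=O)c2C#N)cc1`, carries a methoxyphenyl group on one side of the core and a phenyl group on the other; in this assay compound 1 gives 52.1%. Compound 2, `Cc1nc(-c2ccc(Cl)cc2)sc1C(=O)CSc1nc(-c2ccc(Cl)cc2)c(C#N)c(=O)[nH]1`, carries a 4-chlorophenyl group on both sides; in this assay compound 2 gives 60%. Of the two numbers, compound 2 stands at the upper one, but the gap to compound 1 lies within the usual scatter of such measurements, so the two compounds cannot be told apart on this read-out.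

Compound 3, `Cc1nc(-c2ccccc2)sc1C(=O)CSc1nc(-c2ccc(Cl)cc2)c(C#N)c(=O)[nH]1`, has not yet been measured. It differs from compound 2 in one place only: hydrogen in place of chloro on an aromatic carbon. Since the two measured compounds sit within scatter of one another despite larger differences between them, this smaller change is expected to give no step beyond the scatter, so compound 3 is expected to show roughly the same result as compound 2, with a number 4 percentage points lower from compound 2 to compound 3 (within the scatter) as the expected step. For compound 3 in this assay the estimate is 56%, within a range from 42% to 70%.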

Compound 3, a percentage reported as activity, at one concentration (the size of the read-out at that concentration, not a potency): 63.4%
Estimate against measurement, compound 3: 7.4 percentage points below; the measured number falls inside the stated range.
By their numbers in this assay, from the lowest: compounds 1, 2 and 3 (each within the scatter of the next, the first and the last beyond it).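

Replacing the 4-chlorophenyl group with phenyl gives a number 3.4 percentage points higher from compound 2 to compound 3 (within the scatter) in this assay, so at this place on the aromatic ring, hydrogen and chloro cannot be told apart on this read-out. For the compounds shown here, the other aromatic ring gives the first step beyond the scatter: compound 1 and compound 3 differ in one place there, and chloro in place of methoxy gives a number 11.3 percentage points higher from compound 1 to compound 3 (beyond the scatter), a modest weakening of the effect at the one concentration tested. Nothing measured here bears on why either step has the size it has.

Going by these compounds alone, it remains open whether an amine or a carboxylic acid in place of the chloro, or methoxy at that same place, would move the number beyond the scatter, and whether a group other than chloro or methoxy on the other ring would give a larger step than the one seen between compound 1 and compound 3. These numbers also come from a single concentration, so they show the size of the effect at that concentration and leave the potency of all three compounds unknown.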